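The compounds below may be only part of what the source reports. "The series", "measured", "known", "first", "only" and "open" are said of these compounds alone.

Compound 2 `O=C1NC(=S)/C(=C/c2ccccc2Cl)S1` is the higher of the two compounds measured in a functional assay on NCI-H292 cells (Homo sapiens) for cytotoxicity, read by MTT assay, with a stated time of 72 h, tested at 5 ug/mL (a lower number here means less inhibition of growth, a higher number more inhibition of growth at the concentration tested), where compound 2 gives 34.2%. Within the data shown here, its only neighbour is compound 1 `O=C1NC(=S)/C(=C/c2ccccc2Br)S1`, which in this assay gives 22.9%; the step of a number 11.3 percentage points higher from compound 1 to compound 2 (beyond the scatter) is the one comparison available. Compound 3 `O=C1NC(=S)/C(=C/c2ccccc2F)S1` has not yet been measured in this assay. It differs from compound 2 by fluoro in place of chloro on an aromatic carbon. Among the measured compounds shown here, the single step that bears on this change is the exchange of one halogen for another from compound 1 to compound 2, which raised the read-out by a modest amount beyond the scatter. On that basis a further exchange of halogen is expected to move the read-out by a number 1.8 percentage points higher from compound 2 to compound 3 (within the scatter), in the same direction or not at all beyond the scatter. The value of compound 3 in this assay is therefore estimated at 36%, with a range from 20% to 52%.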

Compound 3, percent growth inhibition at one concentration: 25.2%
Compound 3: the middle estimate sits 10.8 percentage points above what was measured, within the range that was stated.
By their numbers in this assay, from the lowest: compounds 1, 3 and 2 (each within the scatter of the next, the first and the last beyond it).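

In this assay, fluoro in place of chloro on this aromatic carbon gives a number 9 percentage points lower from compound 2 to compound 3 (within the scatter), and fluoro in place of bromo gives a number 2.3 percentage points higher from compound 1 to compound 3 (within the scatter), so neither exchange involving fluoro leaves the scatter. The earlier step between bromo and chloro suggested that the halogen here could matter, but compound 3 now cannot be told apart from either neighbour, and the three halogens form no clear series at this position. Nothing at hand accounts for these numbers.

The compounds shown carry only a halogen at this position, so it remains open how an amine, a methoxy group or a carboxylic acid would read there. On these data alone, it is also open whether any of these halogens would give the same numbers elsewhere on the aromatic ring.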